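Cyano to (morpholin-4-yl)sulfonyl in compound 3

A few compounds are considered here, and "the series" means these few. Any claim that something is new, unique, unknown or untested is made for them only; others in the source may bear on it.

Compound 1: `C#CCN(Cc1ccc2nc(C)nc(O)c2c1)c1cccc(I)c1` with > 5300 nM as a limit
Compound 2: `C#CCN(Cc1ccc2nc(C)nc(O)c2c1)c1ccc(C#N)cc1` with > 5000 nM as a limit
Compound 3: `C#CCN(Cc1ccc2nc(C)nc(O)c2c1)c1ccc(S(=O)(=O)N2CCOCC2)cc1` not yet measured

In a functional assay on L1210 cells (Mus musculus) for inhibition (a higher number here means a weaker inhibitor, a lower number a stronger inhibitor), compound 2 stands only at a limit, > 5000 nM and no number. Compound 1 is likewise only a limit, > 5300 nM and no number. Compound 3 has (morpholin-4-yl)sulfonyl in place of cyano on an aromatic carbon, para to a large group ((morpholin-4-yl)sulfonyl in place of cyano on an aromatic carbon). For the measured compounds named here, the one measured step that bears on this is a step that the two limits leave unreadable from compound 1 to compound 2 and so it offers no size to carry over. With no readable step behind it, the expectation in this assay is for no step beyond the scatter and no firm direction. The expected change is a step that the limit leaves unreadable from compound 2 to compound 3 and it remains an estimate. For compound 3 the estimated value is 7000 nM with an expected range from 2500 nM to 20000 nM in this assay.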

Compound 3, half-maximal inhibitory concentration: 3100 nM
The estimate for compound 3 lay 2.3-fold (0.35 log units) above the measured number, within the range that was stated.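

In this assay, compound 3 is the first of the compounds shown to give a number and not a limit, so a group as large as (morpholin-4-yl)sulfonyl, on an aromatic carbon para to a large group, still leaves a readable value. The change from cyano to (morpholin-4-yl)sulfonyl gives an at least 1.6-fold lower number from compound 2 to compound 3 (0.20 log units; that floor lies within the scatter), so only a floor is known and not the true size of the step. That floor is set by compound 2, which stands only at a limit: the limit of > 5000 nM in this assay, at which 1 of the 3 values shown sits.

The step between the two earlier compounds cannot be read, which leaves compound 3 with no other number to compare against. On these data alone, whether the sulfonyl or the morpholine ring carries the change stays open, as does what an amine or a carboxylic acid would give at this position.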